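Benzyl triazole amides: methoxy pattern and growth inhibition

The source may report more compounds than this note shows. Statements on the series, on what has been measured and on what is new or still open speak of the compounds shown alone.

Compound 1 `O=C(NCc1cn(Cc2ccc(F)cc2)nn1)c1cn(-c2ccccc2)nc1-c1ccc(Cl)cc1`: 1990 nM
Compound 2 `COc1ccc(Cn2cc(CNC(=O)c3cn(-c4ccccc4)nc3-c3ccc(Cl)cc3)nn2)cc1`: 290 nM

In a functional assay on MIA PaCa-2 cells (Homo sapiens) for antiproliferative activity, read by sulforhodamine B assay, with a stated time of 48 h (a higher number here means a weaker inhibitor of growth, a lower number a stronger inhibitor of growth), compound 1 gives 1990 nM, while compound 2 gives 290 nM. Within the data shown here, the single measured step, a 6.9-fold lower number from compound 1 to compound 2 (0.84 log units; beyond the scatter), leaves compound 2 with the lowest number of the two. Compound 3 `COc1cc(Cn2cc(CNC(=O)c3cn(-c4ccccc4)nc3-c3ccc(Cl)cc3)nn2)cc(OC)c1` carries 3,5-dimethoxyphenyl in place of 4-methoxyphenyl on a saturated chain carbon bound to an aromatic nitrogen. Among the measured compounds shown here, no measured step covers moving a methoxy group or adding a second one; the fluoro-to-methoxy step is the only guide, and it does not speak to this change. A step near the scatter, or a modest rise, is expected, a 1.7-fold higher number from compound 2 to compound 3 (0.24 log units; within the scatter). Compound 3 is estimated at 500 nM, ranging from 150 nM to 1600 nM.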

Compound 3, concentration for 50% growth inhibition: 340 nM
Estimate against measurement, compound 3: 1.5-fold (0.17 log units) above; the range from low to high includes it.
By their numbers in this assay, from the lowest: compounds 2 and 3 (each within the scatter of the next); then compound 1.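

On the saturated chain carbon bound to an aromatic nitrogen, 3,5-dimethoxyphenyl and 4-methoxyphenyl do not separate in this assay (a 1.2-fold higher number from compound 2 to compound 3 (0.07 log units; within the scatter)). The distance from the 4-fluorophenyl compound also appears with 3,5-dimethoxyphenyl (a 5.9-fold lower number from compound 1 to compound 3 (0.77 log units; beyond the scatter)), so it is not tied to 4-methoxyphenyl alone. No available data explain these results.

Open, from the compounds shown here alone, is whether a benzyl group carrying an amine or a carboxylic acid would fall with compound 1 or with compound 2 and compound 3. Going by these compounds, a longer chain in place of the saturated chain carbon also remains untested here.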